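A Larger Group on the Amine of Compound 1

The compounds below may be only part of what the source reports. "The series", "measured", "known", "first", "only" and "open" are said of these compounds alone.

Compound 1 `CNC[C@H]1OC(n2cnc3c(N)ncnc32)[C@H](O)[C@@H]1O`: > 600000 nM (a limit)
Compound 2 `CC(=O)OC1C(CN(C)C/C=C\CN)OC(n2cnc3c(N)ncnc32)C1OC(C)=O`: 20000 nM
Compound 3 `CN(C/C=C\CN)CC(CO)OC(CO)n1cnc2c(N)ncnc21`: > 600000 nM (a limit)

All three compounds were tested in a functional assay on L1210 cells (Mus musculus); a higher number here means a weaker inhibitor, a lower number a stronger inhibitor. Compound 1 stands at the limit of > 600000 nM in this assay, at which 2 of the 3 values shown sit. That entry is a limit of the assay and not a number, so the starting point of this step is known only loosely. Compound 3 also gives only a limit. Going by the values given here, compound 2 is the one compound here with an actual number.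

Compound 4 `CN(Cc1ccc(CN)cc1)C[C@H]1OC(n2cnc3c(N)ncnc32)[C@H](O)[C@@H]1O` keeps the core of compound 1 and changes one place: 4-(aminomethyl)benzyl in place of hydrogen on an amine nitrogen. Among the compounds with values here, no measured pair of compounds shows this change directly, so any expectation is rough. A step towards stronger inhibition in this assay is expected, well beyond the usual scatter. The main hint is compound 2 at 20000 nM, whose same nitrogen also carries a chain ending in an amine. Compound 3 has such a chain too and goes against this hint, so the range must stay wide. The expected change is an at least 10-fold lower number from compound 1 to compound 4 (1.00 log units; beyond the scatter). For compound 4 the estimate is 60000 nM, with an expected range from 10000 nM to 300000 nM.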

Compound 4, half-maximal inhibitory concentration: > 600000 nM
Compound 4 gave a limit, no number (the forecaster's own chance of this, stated with the estimate: 25%); middle value at least 10-fold (1.00 log units) from the limit.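

In this assay compound 4 gives > 600000 nM, which is a limit and not a number. Compound 1 also gives only a limit, so no step from compound 1 to compound 4 can be read: the limit of > 600000 nM in this assay, at which 3 of the 4 values shown sit.

The compounds shown leave open whether 4-(aminomethyl)benzyl in place of hydrogen on this amine nitrogen changes inhibition at all.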